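Epimer at the saturated ring carbon: compound 3 to compound 4

A few compounds are considered here, and "the series" means these few. Any claim that something is new, unique, unknown or untested is made for them only; others in the source may bear on it.

Measured so far:
Compound 1, `NC(=O)c1ccc2c(c1)CCO[C@H]2CCN1CCN(c2ccc3cc(F)ccc3c2)CC1`: 96 nM
Compound 2, `N#Cc1ccc2c(N3CCN(CC[C@@H]4OCCc5cc(C(N)=O)ccc54)CC3)cccc2c1`: 178 nM
Compound 3, `C[C@H]1CN(c2cccc3cc(F)ccc23)CCN1CC[C@@H]1OCc2cc(C(N)=O)ccc21`: 64 nM

These three compounds were tested in an assay on cell membranes for displacement of a labelled ligand from Adrenergic receptor alpha-1 (Rattus norvegicus); a higher number here means a weaker inhibitor, a lower number a stronger inhibitor. Compound 3 gives the lowest number of the three, 64 nM, but its gap to compound 1 with 96 nM lies within the scatter, so the two cannot be ordered; only compound 2 with 178 nM stands apart, beyond the scatter.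

Compound 4, `C[C@H]1CN(c2cccc3cc(F)ccc23)CCN1CC[C@H]1OCc2cc(C(N)=O)ccc21`, is the next compound for this assay. Its relation to compound 3 is the two compounds have the same atoms and bonds and differ only in configuration as drawn: 1 of 2 stereo elements differ; a stereocentre at a saturated ring carbon is drawn S in compound 3 and R in compound 4. Going by the values given here, no pair of measured compounds differs in this way, so the data give no step for such a change in configuration and no direction can be read from them. The expectation for compound 4 is therefore set close to compound 3, with a range broad enough to allow a weaker or a stronger result, which is the step of a 2.0-fold higher number from compound 3 to compound 4 (0.31 log units; beyond the scatter). Compound 4 is estimated at 130 nM, between 35 nM and 500 nM.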

Compound 4, inhibition constant: 43 nM
For compound 4 the middle estimate is 3.0-fold (0.48 log units) above the measured one, within the range that was stated.
By their numbers in this assay, from the lowest: compounds 4, 3, 1 and 2 (each within the scatter of the next, the first and the last beyond it).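

In this assay, changing the saturated ring carbon from S to R gives a 1.5-fold lower number from compound 3 to compound 4 (0.17 log units; within the scatter), which lies within the scatter, so neither configuration at this stereocentre can be ranked above the other. Going by these compounds alone, no pair among compound 1, compound 2 and compound 3 differs in one place, so this pair gives the only reading of a single change. The step can be assigned to this stereocentre alone, because nothing else separates the two structures: the fact that compounds 3 and 4 differ only in the configuration as drawn

The compounds shown leave open whether inverting the second stereo element, drawn the same in compound 3 and compound 4, would leave the number just as little changed. They also leave open what a hydroxyl group or an ethyl group on the saturated ring carbon would do in either configuration.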